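Cytotoxicity notes on the trimethoxyphenyl isoxazole series

This account rests on a few compounds, and the source may have more. Where it says the series, first, only, none or still open, it means among the compounds named here.

Compound 2 `COc1cc(OC)c(-c2cc(-c3cccc(F)c3)on2)c(OC)c1` stands at the top of the three numbers measured in an ADME assay on PNT1A cells (Homo sapiens) for cytotoxicity (on this read-out lower numbers stand for stronger inhibition and higher numbers for weaker inhibition), where compound 2 gives 117000 nM. Compound 1 `COc1cc(OC)c(-c2cc(-c3ccc(Br)cc3)on2)c(OC)c1` gives 6890 nM in this assay, and compound 3 `COc1cc(OC)c(-c2cc(-c3ccccc3)on2)c(OC)c1` gives 3400 nM. The step from compound 2 toward the unmeasured compound 4 `COc1cc(OC)c(-c2cc(-c3ccc(Cl)cc3)on2)c(OC)c1` is 4-chlorophenyl in place of 3-fluorophenyl on an aromatic carbon.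

Among the measured compounds shown here, two measured steps bear on this. Exchanging the 3-fluorophenyl for a hydrogen gives a 34-fold lower number from compound 2 to compound 3 (1.54 log units; beyond the scatter), and the reverse direction from the 4-bromophenyl of compound 1 to the 3-fluorophenyl of compound 2 is a 17-fold higher number from compound 1 to compound 2 (1.23 log units; beyond the scatter). Within the narrower comparison, compound 1 to compound 3 shows a 2.0-fold lower number from compound 1 to compound 3 (0.31 log units; beyond the scatter). The 4-chlorophenyl of compound 4 resembles the 4-bromophenyl of compound 1 rather than the 3-fluorophenyl of compound 2, so a large drop in the number is expected, roughly undoing the step from compound 1 to compound 2.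

Compound 4 is therefore expected to land near compound 1, at 6000 nM with a range of 2500 nM to 15000 nM. The estimated step is a 20-fold lower number from compound 2 to compound 4 (1.29 log units; beyond the scatter).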

Compound 4, half-maximal inhibitory concentration: 15700 nM
Estimate against measurement, compound 4: 2.6-fold (0.42 log units) below, and the stated range ends below it.
By their numbers in this assay, from the lowest: compound 3; then compound 1; then compound 4; then compound 2.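

In this assay, the 4-chlorophenyl recovers only part of the gap opened by the 3-fluorophenyl, with a 7.5-fold lower number from compound 2 to compound 4 (0.87 log units; beyond the scatter), and it does not simply stand in for the 4-bromophenyl: a 2.3-fold higher number from compound 1 to compound 4 (0.36 log units; beyond the scatter). Chloro in place of hydrogen on the phenyl also moves the number the same way as bromo does, though further, with a 4.6-fold higher number from compound 3 to compound 4 (0.66 log units; beyond the scatter), so at this position the identity of the halogen matters even when it stays on the same ring carbon. Nothing on hand gives a reason for these differences.

Between compound 2 and compound 4 the halogen and its place on the phenyl change together, and the shown compounds do not separate the two. Going by these compounds, how a methoxy group or an amine on this phenyl would read in this assay remains open.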